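Dropping the Amine Arm from a Weak Inhibitor

The source may report more compounds than this note shows. Statements on the series, on what has been measured and on what is new or still open speak of the compounds shown alone.

Of the compounds shown here, three sharing one acylguanidine core have been tested in a functional assay for inhibition of sodium/hydrogen exchanger (Oryctolagus cuniculus); a higher number here means a weaker inhibitor, a lower number a stronger inhibitor. Compound 1 `Cc1c(C(=O)N=C(N)N)cc(S(C)(=O)=O)c(Cl)c1C` gives 58 nM in this assay, and compound 3 `Cc1cc(N2CCN(c3ncccn3)CC2)c(S(C)(=O)=O)cc1C(=O)N=C(N)N` gives 27 nM. Compound 2 `CCN(CC)Cc1cc(Br)c(S(C)(=O)=O)cc1C(=O)N=C(N)N` stands apart: in this assay compound 2 gives 9500 nM, the highest of the three numbers, and its gaps to compound 1 and to compound 3 both lie beyond the usual scatter of repeated measurements. Compound 4 `CS(=O)(=O)c1cc(C(=O)N=C(N)N)ccc1Br` has not yet been measured. It differs from compound 2 in one place: hydrogen in place of (diethylamino)methyl on an aromatic carbon. Nothing in the measured set shows what a hydrogen in place of (diethylamino)methyl on an aromatic carbon does, but compound 1 and compound 3, which lack that group, both give much lower numbers than compound 2. A step toward a lower number is therefore expected for compound 4, with the shift from compound 2 estimated as a 12-fold lower number from compound 2 to compound 4 (1.07 log units; beyond the scatter). Compound 4 is expected to give about 800 nM in this assay, with a likely range from 150 nM to 4000 nM.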

Compound 4, half-maximal inhibitory concentration: 180 nM
Beside the measured number, compound 4's estimate is 4.4-fold (0.65 log units) above it; the range from low to high includes it.
By their numbers in this assay, from the lowest: compound 3; then compound 1; then compound 4; then compound 2.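

In this assay the swap of (diethylamino)methyl for hydrogen on this aromatic carbon gives a 53-fold lower number from compound 2 to compound 4 (1.72 log units; beyond the scatter) as the result of that single change. The earlier compounds shown here differ from compound 2 in more than one place, so they could only hint at the effect of this group, whereas this pair isolates it, with the bromo and methylsulfonyl groups kept in place. At this carbon, para to the methylsulfonyl group, the choice between these two substituents therefore matters greatly, and hydrogen gives the lower number of the two.

Nothing available here explains why the number moves so far. The compounds shown also leave open whether a smaller group on this carbon, such as a methyl or an aminomethyl, would give a number closer to compound 2 or to compound 4.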